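The source may hold more compounds than are shown below. What is called first, only, known or untested is meant among the compounds shown, and "the series" means these compounds.

Of the compounds shown here, three have been measured in a functional assay on HOS cells (Homo sapiens) for inhibition, read by MTT assay, with a stated time of 72 h (on this read-out higher numbers stand for weaker inhibition and lower numbers for stronger inhibition), and all share one core. Compound 1 `O=C(CCC(=O)OCCCCCCSc1ccc([N+](=O)[O-])c2nonc12)Nc1ccccc1` gives 2120 nM. Compound 2 `Cc1ccccc1NC(=O)CCC(=O)OCCCCCCSc1ccc([N+](=O)[O-])c2nonc12` gives 4020 nM, and compound 3 `COc1ccccc1NC(=O)CCC(=O)OCCCCCCSc1ccc([N+](=O)[O-])c2nonc12` gives 2850 nM. Compound 1 has the lowest of the three numbers, but the steps of a 1.9-fold higher number from compound 1 to compound 2 (0.28 log units; within the scatter) and a 1.3-fold higher number from compound 1 to compound 3 (0.13 log units; within the scatter) both stay within the scatter, so the three compounds cannot be told apart on these data.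

Compound 4 `CN(C)CCNC(=O)CCC(=O)OCCCCCCSc1ccc([N+](=O)[O-])c2nonc12` has not yet been measured. It differs from compound 1 by 2-(dimethylamino)ethyl in place of phenyl on an amide-type nitrogen. Among the measured compounds shown here, none of the measured steps touches this amide-type nitrogen: the steps from compound 1 to compound 2 and from compound 1 to compound 3 only vary a group on the phenyl ring, and both stay within the scatter, so they say nothing about removing the phenyl ring altogether. For the measured compounds named here, no step of this kind is available. With no guide, the expected step of a 1.4-fold higher number from compound 1 to compound 4 (0.15 log units; within the scatter) is small and its direction is uncertain. Compound 4 is therefore estimated at 3000 nM, within a wide range from 800 nM to 12000 nM.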

Compound 4, half-maximal inhibitory concentration: 5020 nM
Compound 4: middle estimate off by 1.7-fold (0.22 log units), on the low side, within the range that was stated.
By their numbers in this assay, from the lowest: compounds 1, 3, 2 and 4 (each within the scatter of the next, the first and the last beyond it).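

In this assay, among the compounds shown here, changing the group on the amide-type nitrogen gives a larger step than any change on the phenyl ring: 2-(dimethylamino)ethyl in place of phenyl gives a 2.4-fold higher number from compound 1 to compound 4 (0.37 log units; beyond the scatter) and is the only step here that clears the scatter, though only modestly. The same kind of change made from the ring-substituted compounds stays within the scatter, with a 1.8-fold higher number from compound 3 to compound 4 (0.25 log units; within the scatter) and a 1.2-fold higher number from compound 2 to compound 4 (0.10 log units; within the scatter), so compound 4 can be told apart only from compound 1. Nothing measured here offers a reason for the step from compound 1.

The change removes the phenyl ring and brings in an amine at once, so the compounds shown leave open which of the two goes with the higher number. A plain butyl chain or a benzyl group on the same nitrogen would help to separate them.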